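A Hydroxy Group Added to Compound 3

The compounds below may be only part of what the source reports. "The series", "measured", "known", "first", "only" and "open" are said of these compounds alone.

In a functional assay on PANC-1 cells (Homo sapiens) for antiproliferative activity, read by MTT assay, with a stated time of 48 h (a higher number here means a weaker inhibitor, a lower number a stronger inhibitor), compound 1 `COc1ccc(-c2c(Nc3ccc(C)cc3)c3ccccc3oc2=O)cc1` gives 66100 nM, and compound 3 `COc1ccc(-c2c(Nc3cccc(C(F)(F)F)c3)c3ccccc3oc2=O)cc1` gives 49100 nM. For compound 2 `COc1ccc(-c2c(Nc3ccc(NC(C)=O)cc3)c3ccccc3oc2=O)cc1` the entry reads "not determined" (no result reported), so it offers no comparison. Among the measured compounds shown here, the only measured step, with 3-(trifluoromethyl)phenyl in place of 4-methylphenyl on the nitrogen, is a 1.3-fold lower number from compound 1 to compound 3 (0.13 log units; within the scatter). Compound 3 therefore stands level with compound 1, and neither can be ranked above the other.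

Compound 4 `COc1ccc(-c2c(Nc3cccc(C(F)(F)F)c3)c3ccc(O)cc3oc2=O)cc1` differs from compound 3 in one place: hydroxy in place of hydrogen on an aromatic carbon. This is hydroxy in place of hydrogen on an aromatic carbon of a six-membered aromatic ring of carbon only, part of a fused or bridged system of two rings. For the measured compounds named here, the measured step concerns a different group, and no measured compound carries this hydroxy, so the data give only weak guidance. The expectation is therefore no step beyond the scatter, with real uncertainty in either direction. The expected change is a 1.2-fold lower number from compound 3 to compound 4 (0.07 log units; within the scatter). Compound 4 is estimated at 42000 nM, within an expected range of 14000 nM to 100000 nM.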

Compound 4, half-maximal inhibitory concentration: 67200 nM
Compound 4: the middle estimate sits 1.6-fold (0.20 log units) below what was measured; low and high end bracket the measured number.
By their numbers in this assay, from the lowest: compounds 3, 1 and 4 (each within the scatter of the next).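

In this assay, placing a hydroxy on an aromatic carbon of the fused system of two rings gives a 1.4-fold higher number from compound 3 to compound 4 (0.14 log units; within the scatter), a step that stays within the usual scatter. The earlier step concerned the group on the nitrogen, whereas this one shows that a change on the fused ring system can also leave the number within the scatter, even though it adds a hydrogen-bond donor and a hydrogen-bond acceptor. No supporting measurement bears on this result.

As far as these compounds go, whether the same carbon would give a similar reading with an amine or a carboxylic acid in place of the hydroxy remains open. From the compounds shown here alone, it is also open whether a hydroxy on another carbon of this ring would give a step beyond the scatter.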